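The source may hold more compounds than are shown below. What is called first, only, known or untested is meant among the compounds shown, and "the series" means these compounds.

Measured compounds:
- compound 1, `CCCCCn1ccc2cc(/C(C)=C/C(=O)Nc3ccccc3OCCCC(=O)O)ccc21`, 23 nM
- compound 2, `CCCC(C(C)C)n1ccc2cc(/C(C)=C/C(=O)Nc3ccccc3OCCCC(=O)O)ccc21`, 7.2 nM
- compound 3, `CCCCC(C)n1ccc2cc(/C(C)=C/C(=O)Nc3ccccc3OCCCC(=O)O)ccc21`, 6 nM

In an assay on Prostate gland for inhibition of steroid 5-alpha-reductase (Rattus norvegicus) (a higher number here means a weaker inhibitor, a lower number a stronger inhibitor), compound 3 gives 6 nM, the lowest of the three numbers, though its gap to compound 2 lies within the scatter and only its gap to compound 1 stands beyond it. Two steps are recorded from compound 1: a 3.2-fold lower number from compound 1 to compound 2 (0.50 log units; beyond the scatter) and a 3.8-fold lower number from compound 1 to compound 3 (0.58 log units; beyond the scatter), both modest and both in the same direction once the pentyl chain carries a branch at the carbon bound to the aromatic nitrogen. Between the two branched compounds the step is a 1.2-fold lower number from compound 2 to compound 3 (0.08 log units; within the scatter), within the scatter, so the size of the branch itself made no difference that can be read.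

Compound 4, `CCCCC(CC)n1ccc2cc(/C(C)=C/C(=O)Nc3ccccc3OCCCC(=O)O)ccc21`, is not yet measured. It differs from compound 3 by methyl in place of hydrogen on a saturated chain carbon, two bonds along the chain from an aromatic nitrogen. For the measured compounds named here, this enlarges the existing branch rather than adding a new one, and the only comparable step, from compound 2 to compound 3, was within the scatter. No change beyond the scatter in this assay is therefore expected, and compound 4 is estimated at 6.5 nM, with a range of 3 nM to 14 nM, meaning an expected step of a 1.1-fold higher number from compound 3 to compound 4 (0.03 log units; within the scatter).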

Compound 4, half-maximal inhibitory concentration: 7.1 nM
Compound 4: middle estimate off by 1.1-fold (0.04 log units), on the low side, within the range that was stated.
By their numbers in this assay, from the lowest: compounds 3, 4 and 2 (each within the scatter of the next); then compound 1.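

Taking the branch from methyl to ethyl, with the rest of the 1-methylpentyl group unchanged, gives a 1.2-fold higher number from compound 3 to compound 4 (0.07 log units; within the scatter) in this assay, so this position reads flat for a change confined to the branch itself, which the earlier comparison of 1-isopropylbutyl with 1-methylpentyl could not show because both arms differed there. For the compounds shown here, the 1-ethylpentyl and 1-isopropylbutyl groups also read alike, with a 1.0-fold lower number from compound 2 to compound 4 (0.01 log units; within the scatter), and this places all three branched groups in one band in this assay, with no compound among them going against it. Against the unbranched pentyl group, ethyl in place of hydrogen gives a 3.2-fold lower number from compound 1 to compound 4 (0.51 log units; beyond the scatter), so the separation from pentyl seen with the two earlier branched groups also holds for the 1-ethylpentyl group.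

Nothing available speaks to what lies behind this flat reading. From the compounds shown here alone, it remains open how far the band extends: whether a propyl or butyl branch at the same carbon, a cyclopropyl group there, or a hydroxyl or an amine on the branch would stay within it, and whether the two mirror-image forms at the branched carbon give the same number.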